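This account rests on a few compounds, and the source may have more. Where it says the series, first, only, none or still open, it means among the compounds named here.

Measured compounds in an assay on isolated protein for inhibition of DNA topoisomerase 1 (Homo sapiens), with a stated time of 30 min, tested at 20 uM; on this read-out lower numbers stand for a weaker effect and higher numbers for a stronger effect at the one concentration tested:
Compound 1 `Oc1ccc(-c2cc(-c3ccoc3)cc(-c3cccc(O)c3)n2)cc1`, in this assay compound 1 gives 1.3%.
Compound 2 `Oc1ccc(-c2cc(-c3ccoc3)cc(-c3ccc(O)cc3)n2)cc1`, in this assay compound 2 gives 0%.
Compound 3 `Oc1ccc(-c2cc(-c3cccnc3)cc(-c3cccc(O)c3)n2)cc1`, in this assay compound 3 gives 2.8%.

Compound 4 `Oc1ccc(-c2cc(-c3cccnc3)cc(-c3ccc(O)cc3)n2)cc1` has not yet been measured. It differs from compound 3 by one change, (4-hydroxyphenyl in place of 3-hydroxyphenyl on an aromatic carbon). The same change is made between compound 1 and compound 2, where it gave a number 1.3 percentage points lower from compound 1 to compound 2 (within the scatter). The two cores differ as well, (pyridin-3-yl in place of furan-3-yl on an aromatic carbon), and that difference gave a number 1.5 percentage points higher from compound 1 to compound 3 (within the scatter). Around the changed place the surroundings are not identical: in compound 1 the place is meta to a furan-3-yl group, in compound 3 meta to a pyridin-3-yl group, so this is the same kind of change, not the same change. Since all three measured numbers sit close together and the earlier step was within the scatter, the expected step is a number 1.3 percentage points lower from compound 3 to compound 4 (within the scatter), resting on compound 1 to compound 2 with a number 1.3 percentage points lower from compound 1 to compound 2 (within the scatter). Compound 4 is therefore estimated at 1.5%, between -3% and 6%.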

Compound 4, a percentage reported as inhibition, at one concentration (the size of the read-out at that concentration, not a potency): 5%
For compound 4 the middle estimate is 3.5 percentage points below the measured one; measured number inside the range.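

In this assay, 4-hydroxyphenyl in place of 3-hydroxyphenyl gives a number 2.2 percentage points higher from compound 3 to compound 4 (within the scatter), and pyridin-3-yl in place of furan-3-yl gives a number 5 percentage points higher from compound 2 to compound 4 (within the scatter). The first change shows no detectable dependence on the core: the same change on two cores in this assay, a number 1.3 percentage points lower (within the scatter) from compound 1 to compound 2 and a number 2.2 percentage points higher (within the scatter) from compound 3 to compound 4, 3.5 percentage points apart, within the scatter of two such steps. The second reads the same, but steps this small show only that no difference can be seen here, not that either change would carry over equally to a compound with a clear effect: the same change on two cores in this assay, a number 1.5 percentage points higher (within the scatter) from compound 1 to compound 3 and a number 5 percentage points higher (within the scatter) from compound 2 to compound 4, 3.5 percentage points apart, within the scatter of two such steps.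

The compounds shown leave open whether any compound in this series gives a clear effect in this assay. As far as these compounds go, it also stays open what an amine or a carboxylic acid in place of the hydroxyl would do.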